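Step from compound 3 to compound 4 on the shared core

This account rests on a few compounds, and the source may have more. Where it says the series, first, only, none or still open, it means among the compounds named here.

Compound 3 `N/C(=N\O)c1c(Cl)n(C2O[C@H](CO)[C@@H](O)[C@H]2O)c2cc(Cl)c(Cl)cc12` stands at the limit of a functional assay on KB cells (Homo sapiens) for cytotoxicity, read by spectrophotometry and crystal violet staining; a higher number here means a weaker inhibitor, a lower number a stronger inhibitor: in this assay compound 3 gives > 100000 nM, which is a limit of the assay and not a number. Compound 1 `CO/N=C/c1c(Cl)n(C2O[C@H](CO)[C@@H](O)[C@H]2O)c2cc(Cl)c(Cl)cc12` gives 70000 nM in this assay, and compound 2 `N/C(S)=N/N=C/c1c(Cl)n(C2O[C@H](CO)[C@@H](O)[C@H]2O)c2cc(Cl)c(Cl)cc12` gives 65000 nM. Going by the values given here, the measured steps, a 1.1-fold lower number from compound 1 to compound 2 (0.03 log units; within the scatter), an at least 1.4-fold higher number from compound 1 to compound 3 (0.15 log units; that floor lies within the scatter) and an at least 1.5-fold higher number from compound 2 to compound 3 (0.18 log units; that floor lies within the scatter), all stay within the scatter, and the limit of > 100000 nM in this assay, at which 1 of the 3 values shown sits, is the only evidence that bears on them. Compound 4 `NC(=O)N/N=C/c1c(Cl)n(C2O[C@H](CO)[C@@H](O)[C@H]2O)c2cc(Cl)c(Cl)cc12` differs from compound 3 by a group of 6 heavy atoms (2 carbon, 3 nitrogen, 1 oxygen; no ring) in place of a group of 4 heavy atoms (1 carbon, 2 nitrogen, 1 oxygen; no ring), on an aromatic carbon. The nearest measured change, an at least 1.5-fold higher number from compound 2 to compound 3 (0.18 log units; that floor lies within the scatter), runs in the opposite direction to the change here and lay within the scatter, and a 1.1-fold lower number from compound 1 to compound 2 (0.03 log units; within the scatter) likewise lay within the scatter. No step beyond the scatter is therefore expected in this assay, with a return to a measurable number as the likelier outcome. The value of compound 4 is estimated at 70000 nM, between 35000 nM and 150000 nM. The expected step is an at least 1.4-fold lower number from compound 3 to compound 4 (0.15 log units; that floor lies within the scatter).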

Compound 4, half-maximal inhibitory concentration: > 100000 nM
Compound 4: only a limit was reported (the forecaster's own chance of this, stated with the estimate: 35%); middle value at least 1.4-fold (0.15 log units) away from the limit.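

In this assay compound 4 gives > 100000 nM, which is a limit of the assay and not a number. Ureido in place of methoxy on the double-bonded nitrogen gives an at least 1.4-fold higher number from compound 1 to compound 4 (0.15 log units; that floor lies within the scatter), and the change on that same nitrogen in the other measured pair gives an at least 1.5-fold higher number from compound 2 to compound 4 (0.18 log units; that floor lies within the scatter), while the step between the two limits cannot be read. A group of 6 heavy atoms on this aromatic carbon gives a measured number in compound 2 but only a limit in compound 4, so the size of the group alone does not settle the outcome, and the data here reach only as far as a ceiling: the limit of > 100000 nM in this assay, at which 2 of the 4 values shown sit.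

Going by these compounds, whether compound 3 and compound 4 differ at all beyond the limit stays open. Also open, on these data alone, is whether a primary amine or a carboxylic acid on this aromatic carbon would move the number beyond the scatter.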